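Replacing 2,6-difluorophenyl with 2,6-dichlorophenyl on the amide carbonyl

A few compounds are considered here, and "the series" means these few. Any claim that something is new, unique, unknown or untested is made for them only; others in the source may bear on it.

compound 1 `COc1ccc(C(=O)Nc2ccc3c(c2)/C(=C/Nc2cccc(N4CCN(C)CC4)c2)C(=O)N3)cc1` gives 2050 nM
compound 2 `CN1CCN(c2cccc(N/C=C3\C(=O)Nc4ccc(NC(=O)c5cccc(F)c5)cc43)c2)CC1` gives 2910 nM
compound 3 `CN1CCN(c2cccc(N/C=C3\C(=O)Nc4ccc(NC(=O)c5c(F)cccc5F)cc43)c2)CC1` gives 2030 nM

These three values come from a functional assay on A2780 cells (Homo sapiens) for inhibition, read by sulforhodamine B assay, with a stated time of 3 days (on this read-out higher numbers stand for weaker inhibition and lower numbers for stronger inhibition), and cannot be ordered. In this assay compound 3 (2030 nM) stands within the scatter of both other compounds. The next compound, compound 4 `CN1CCN(c2cccc(N/C=C3\C(=O)Nc4ccc(NC(=O)c5c(Cl)cccc5Cl)cc43)c2)CC1`, carries 2,6-dichlorophenyl in place of 2,6-difluorophenyl on a carbonyl carbon, with the amide-type nitrogen as its other neighbour (2,6-dichlorophenyl in place of 2,6-difluorophenyl on a carbonyl carbon).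

Among the compounds with values here, no measured step makes this exact exchange, so the nearest evidence comes from the other replacements at the same place. These are a 1.4-fold higher number from compound 1 to compound 2 (0.15 log units; within the scatter), a 1.0-fold lower number from compound 1 to compound 3 (0.00 log units; within the scatter) and a 1.4-fold lower number from compound 2 to compound 3 (0.16 log units; within the scatter), and all three stay within the scatter. The group has so far changed the read-out little across these three compounds, although that is a thin basis for a new group.

The expected change is therefore none beyond the scatter, and the estimated step is a 1.1-fold higher number from compound 3 to compound 4 (0.05 log units; within the scatter). For compound 4 the estimated value is 2300 nM, with an expected range from 1100 nM to 4800 nM.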

Compound 4, half-maximal inhibitory concentration: 2140 nM
Compound 4: middle estimate off by 1.1-fold (0.03 log units), on the high side; the measured number falls inside the stated range.
By their numbers in this assay, from the lowest: compounds 3, 1, 4 and 2 (each within the scatter of the next).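

In this assay, 2,6-dichlorophenyl in place of 2,6-difluorophenyl on the carbonyl carbon gives a 1.1-fold higher number from compound 3 to compound 4 (0.02 log units; within the scatter), so exchanging the halogen while keeping the two-halogen phenyl group also stays within the scatter. The steps from the other two compounds read the same way, with a 1.4-fold lower number from compound 2 to compound 4 (0.13 log units; within the scatter) and a 1.0-fold higher number from compound 1 to compound 4 (0.02 log units; within the scatter), so the four aryl groups at this place now give values that cannot be ordered. Nothing measured here accounts for these values.

On these data alone, it remains open whether this flat picture extends beyond substituted phenyl groups, for example to a carbonyl carbon bearing a piperidine, a carboxylic acid or a longer alkyl chain. The compounds also leave open whether any group at this place can move the read-out beyond the scatter.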